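The source may report more compounds than this note shows. Statements on the series, on what has been measured and on what is new or still open speak of the compounds shown alone.

Measured compounds in an ADME assay on HepG2 cells (Homo sapiens) for cytotoxicity, read by resazurin assay, with a stated time of 48 h; on this read-out higher numbers stand for an effect only at larger amounts of compound and lower numbers for an effect already at smaller amounts:

Compound 1 `O=C(Nc1ccc(F)c(-c2nc3ncc(-c4ccc(F)cc4F)cc3[nH]2)c1)N1CCCC1` gives 32400 nM.
Compound 2 `O=C(Nc1ccc(F)c(-c2nc3ncc(-c4cccc(F)c4F)cc3[nH]2)c1)N1CCCC1` gives only a limit of the assay, > 50000 nM.
Compound 3 `O=C(Nc1ccc(F)c(-c2nc3ncc(-c4cc(F)cc(F)c4)cc3[nH]2)c1)N1CCCC1` gives only a limit of the assay, > 50000 nM.

Among the compounds with values here, compound 1 thus stands as the only compound with a read number in this assay; the two other values are limits. Compound 4 `O=C(Nc1ccc(F)c(-c2nc3ncc(-c4ccccc4F)cc3[nH]2)c1)N1CCCC1` differs from compound 1 by hydrogen in place of fluoro on an aromatic carbon. Within the data shown here, no measured step makes exactly this change, but two steps alter the same difluorophenyl ring: an at least 1.5-fold higher number from compound 1 to compound 2 (0.18 log units; that floor lies within the scatter) and an at least 1.5-fold higher number from compound 1 to compound 3 (0.18 log units; that floor lies within the scatter). From the compounds shown here alone, both end at the limit of > 50000 nM in this assay, at which 2 of the 3 values shown sit, so their true size is unknown, and their floors lie within the scatter. Moving fluoro groups around that ring therefore shows no effect in this assay beyond the scatter, and removing one fluoro is expected to behave the same way, with a fair chance of again reaching the limit. The expected step is a 1.2-fold higher number from compound 1 to compound 4 (0.09 log units; within the scatter). Compound 4 is estimated at 40000 nM, within a range from 15000 nM to 100000 nM.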

Compound 4, half-maximal effective concentration: > 50000 nM
Compound 4 ended at the assay's limit (the forecaster's own chance of this, stated with the estimate: 45%); middle value at least 1.2-fold (0.09 log units) from the limit.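

In this assay, replacing fluoro with hydrogen on the carbon para to a large group gives an at least 1.5-fold higher number from compound 1 to compound 4 (0.18 log units; that floor lies within the scatter). So removing this fluoro, and not only moving fluoro groups around the ring, gives a step that cannot be shown to exceed the usual scatter. Compound 1 remains the only compound of the four with a read number, and the steps among compound 2, compound 3 and compound 4 cannot be read, since all three values are limits: the limit of > 50000 nM in this assay, at which 3 of the 4 values shown sit.

From the compounds shown here alone, how far the true values of compound 2, compound 3 and compound 4 lie past that limit remains open, so any real difference from compound 1 has no known size. Also open, going by these compounds, is what a different group at this position, such as an amine or a carboxylic acid, would do to the number in this assay.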